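Swapping the amide tail of a spirocyclic cholesterol-transporter ligand

This account rests on a few compounds, and the source may have more. Where it says the series, first, only, none or still open, it means among the compounds named here.

The measured compounds:
compound 1 `CC(C)(C)OC(=O)NC1CCN(C(=O)CN2CN(c3ccccc3)C3(CCN(C(=O)c4ccc(C(C)(C)C)cc4)CC3)C2=O)CC1`, 8300 nM
compound 2 `CC(C)(C)c1ccc(C(=O)N2CCC3(CC2)C(=O)N(CC(=O)NCCCN)CN3c2ccccc2)cc1`, 4200 nM
compound 3 `CC(C)(C)c1ccc(C(=O)N2CCC3(CC2)C(=O)N(CC(=O)NCCCCCNS(C)(=O)=O)CN3c2ccccc2)cc1`, 5500 nM

In an assay on HEK293 cells for displacement of a labelled ligand from NPC1-like intracellular cholesterol transporter 1 (Homo sapiens) (on this read-out higher numbers stand for weaker inhibition and lower numbers for stronger inhibition), compound 3 gives 5500 nM, the second highest of the three numbers; compound 2 gives 4200 nM and compound 1 gives 8300 nM, both within the scatter of compound 3. Compound 4 `CCOC(=O)C1CCN(C(=O)CN2CN(c3ccccc3)C3(CCN(C(=O)c4ccc(C(C)(C)C)cc4)CC3)C2=O)CC1` has not yet been measured. It differs from compound 3 by 4-(ethoxycarbonyl)piperidin-1-yl in place of (5-(methanesulfonamido)pentyl)amino on a carbonyl carbon. Among the measured compounds shown here, one measured step bears on this change: a 1.3-fold higher number from compound 2 to compound 3 (0.12 log units; within the scatter), which shows that altering the tail beyond the amide on the shared core leaves the number where it was. Compound 1, which also carries a piperidine amide in this position, gives 8300 nM, again within the scatter of compound 3. For the measured compounds named here, compound 4 is therefore expected to stay close to compound 3, with no step in this assay beyond the scatter, perhaps drifting slightly toward the number of compound 1. The estimate for compound 4 is 7000 nM, with a range from 3000 nM to 18000 nM. This expectation amounts to a 1.3-fold higher number from compound 3 to compound 4 (0.10 log units; within the scatter).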

Compound 4, half-maximal inhibitory concentration: 3100 nM
Compound 4: the middle estimate sits 2.3-fold (0.35 log units) above what was measured; low and high end bracket the measured number.
By their numbers in this assay, from the lowest: compounds 4, 2, 3 and 1 (each within the scatter of the next, the first and the last beyond it).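

In this assay, the piperidine amide bearing ethoxycarbonyl stays within the scatter of both open-chain tails (a 1.8-fold lower number from compound 3 to compound 4 (0.25 log units; within the scatter); a 1.4-fold lower number from compound 2 to compound 4 (0.13 log units; within the scatter)), so on this carbonyl carbon a six-membered ring can replace a chain, and a group with 0 hydrogen-bond donors can replace (5-(methanesulfonamido)pentyl)amino with its 2, without a step beyond the scatter. Among the compounds shown here, the only step beyond the scatter lies on the piperidine itself, where ethoxycarbonyl replaces (tert-butoxycarbonyl)amino on a saturated ring carbon, a modest step (a 2.7-fold lower number from compound 1 to compound 4 (0.43 log units; beyond the scatter)), showing that with the ring amide kept, the group on that ring carbon can shift the number. Nothing available accounts for that step. The compounds shown leave open whether a free carboxylic acid in place of the ethyl ester would hold the number of compound 4. They also leave open whether a plain amine on that ring carbon would do so.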